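Thiophene-linked benzamidines: methoxy to chloro on the terminal ring

A few compounds are considered here, and "the series" means these few. Any claim that something is new, unique, unknown or untested is made for them only; others in the source may bear on it.

Measured so far:
compound 1 `COc1ccc(-c2ccc(-c3ccc(C(=N)N)cc3)s2)cc1` gives 2140 nM
compound 2 `N=C(N)c1ccc(-c2ccc(-c3cc(Cl)cc(Cl)c3)s2)cc1` gives 2050 nM
compound 3 `COc1ccc(-c2ccc(-c3ccc(C(=N)N)c(F)c3)s2)cc1` gives 4820 nM

In a functional assay on Hs-578T cells (Homo sapiens) for inhibition, read by sulforhodamine B assay, with a stated time of 48 h (a higher number here means a weaker inhibitor of growth, a lower number a stronger inhibitor of growth), compound 1 stands second highest of the three numbers. Compound 2 sits within the scatter of compound 1, so nothing separates them; compound 3 lies higher, beyond the scatter, through a 2.3-fold higher number from compound 1 to compound 3 (0.35 log units; beyond the scatter).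

Compound 4 `N=C(N)c1ccc(-c2ccc(-c3ccc(Cl)cc3)s2)cc1` is not yet measured. It differs from compound 1 in a single place: chloro in place of methoxy on an aromatic carbon. Going by the values given here, the one measured step, fluoro in place of hydrogen on an aromatic carbon, touches a different ring and a different kind of change, so it does not bear directly on this one. Among the compounds with values here, the only hint comes from compound 2, where the methoxy-bearing ring is replaced by a chlorine-bearing ring and the value stays level with compound 1; that is a comparison of two values, not a measured step of this exact change.

With nothing pointing either way, no step beyond the scatter is expected, and a 1.1-fold lower number from compound 1 to compound 4 (0.03 log units; within the scatter) is the estimated change. Compound 4 is therefore expected to give 2000 nM, within a range from 1000 nM to 4500 nM.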

Compound 4, concentration for 50% growth inhibition: 200 nM
Compound 4: the middle estimate sits 10-fold (1.00 log units) above what was measured, outside the stated range (below it).
By their numbers in this assay, from the lowest: compound 4; then compounds 2 and 1 (each within the scatter of the next); then compound 3.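

In this assay the place para to a large group on the terminal ring turns out to be sensitive: chloro in place of methoxy gives an 11-fold lower number from compound 1 to compound 4 (1.03 log units; beyond the scatter), a large change from swapping a single substituent. Going by these compounds alone, the only step seen before, a 2.3-fold higher number from compound 1 to compound 3 (0.35 log units; beyond the scatter), was modest, ran in the opposite direction and lay on a different ring, so the earlier compounds gave no sign of a change of this size. No measurement at hand bears on the reason for this step.

Going by these compounds, whether the gain comes from chloro itself or from the loss of methoxy stays open, and a hydrogen, a methyl, a bromo or an amine at this place would separate the two. Also open, on these data alone, is whether the fluoro change on the other ring carries the same penalty on the chloro compound.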